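Cyano in Place of Dimethylcarbamoyl on Compound 1

The source may hold more compounds than are shown below. What is called first, only, known or untested is meant among the compounds shown, and "the series" means these compounds.

In an in vitro ADME assay on microsomes from liver (Homo sapiens) for metabolic stability (a higher number here means faster removal of the compound, a lower number slower removal), compound 1 (`CN(C)C(=O)c1cc(Cl)c(NC(=O)N2CCN3C(=O)N([C@H]4C[C@@H]4c4ccccc4)C(=O)[C@@H]3C2)c(Cl)c1`) reads 49000 mL.min-1.g-1 and compound 2 (`O=C(Nc1ccnn1-c1cccc(Cl)c1)N1CCN2C(=O)N([C@H]3C[C@@H]3c3ccccc3)C(=O)[C@@H]2C1`) reads 62000 mL.min-1.g-1 so the two stand within the usual scatter of each other. Compound 3 (`N#Cc1cc(Cl)c(NC(=O)N2CCN3C(=O)N([C@H]4C[C@@H]4c4ccccc4)C(=O)[C@@H]3C2)c(Cl)c1`) has cyano in place of dimethylcarbamoyl on an aromatic carbon, meta to two chloro groups and para to a large group. Within the data shown here, no measured pair shows a change of this kind, so no step beyond the scatter is expected in this assay in either direction. The estimate is a 1.1-fold lower number from compound 1 to compound 3 (0.04 log units; within the scatter) for now. Compound 3 is expected at 45000 mL.min-1.g-1 with an estimated range from 22000 mL.min-1.g-1 to 90000 mL.min-1.g-1 in this measurement.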

Compound 3, intrinsic clearance in microsomes: 66000 mL.min-1.g-1
Estimate against measurement, compound 3: 1.5-fold (0.17 log units) below, and the stated range covers the measured number.
By their numbers in this assay, from the lowest: compounds 1, 2 and 3 (each within the scatter of the next).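

Among these compounds, this is the first pair that isolates a change at this position, and in this assay it gives a 1.3-fold higher number from compound 1 to compound 3 (0.13 log units; within the scatter). Cyano in place of dimethylcarbamoyl on this aromatic carbon, para to a large group, therefore gives a reading that cannot be told apart from that of compound 1. No available data offer an explanation for the two groups reading alike. A single pair cannot show whether this position matters for clearance in general. Going by these compounds, whether a carboxylic acid or an amine here would give a step beyond the scatter remains open.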